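This account rests on a few compounds, and the source may have more. Where it says the series, first, only, none or still open, it means among the compounds named here.

Three compounds have been measured in an ADME assay on BEAS-2B cells (Homo sapiens) for cytotoxicity, read by MTT assay, with a stated time of 72 h; on this read-out higher numbers stand for weaker inhibition of growth and lower numbers for stronger inhibition of growth:

compound 1, `N#C[Se]c1ccc(NC(=O)OCc2ccc([N+](=O)[O-])cc2)cc1`: 32800 nM
compound 2, `N#C[Se]c1ccc(NC(=O)Oc2ccc(F)cc2)cc1`: 45600 nM
compound 3, `CCCCOC(=O)Nc1ccc([Se][Se]c2ccc(NC(=O)OCCCC)cc2)cc1`: 49600 nM

Compound 2 stands in the middle of these three numbers. The value of compound 3 is the nearest to it and the value of compound 1 the furthest, but both gaps fall within the usual scatter of repeated measurements, so on this read-out the three compounds cannot be told apart.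

Compound 4, `N#C[Se]c1ccc(NC(=O)Oc2ccccc2)cc1`, has not yet been measured in this assay. It differs from compound 2 in a single place: hydrogen in place of fluoro on an aromatic carbon. Within the data shown here, no step between two measured compounds has been characterised in this set, so the measured data say nothing directly about what this change does. Since all three measured values already lie within the scatter of one another, the step of a 1.0-fold lower number from compound 2 to compound 4 (0.01 log units; within the scatter) is expected to be small, none beyond the usual scatter. Compound 4 is therefore estimated at 45000 nM, with a range from 22000 nM to 90000 nM.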

Compound 4, concentration for total growth inhibition: 38200 nM
Beside the measured number, compound 4's estimate is 1.2-fold (0.07 log units) above it; measured number inside the range.
By their numbers in this assay, from the lowest: compounds 1, 4, 2 and 3 (each within the scatter of the next).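

In this assay, among these compounds, the first comparison in this set between compounds that differ in one place is a 1.2-fold lower number from compound 2 to compound 4 (0.08 log units; within the scatter), for hydrogen in place of fluoro on an aromatic carbon, para to a large group. At this position, fluoro and hydrogen therefore cannot be told apart on this read-out. Until now, the closeness of the values rested only on compounds that differ in more than one place, whereas this pair isolates a single change. Nothing available bears on why the two compounds behave alike.

The compounds shown leave open whether an amine, a carboxylic acid or a longer chain at this same place would give a step beyond the scatter. They also leave open whether this change would have a similarly small effect on the core of compound 1.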